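The source may report more compounds than this note shows. Statements on the series, on what has been measured and on what is new or still open speak of the compounds shown alone.

Measured compounds:
Compound 1 `CCOc1ccc(/C=C(/Sc2ccc(C)cc2)C(=O)c2ccc(Cl)cc2)cc1OC` — in a functional assay on DU-145 cells (Homo sapiens) for inhibition, read by trypan blue exclusion, with a stated time of 96 h (a lower number here means a stronger inhibitor of growth, a higher number a weaker inhibitor of growth), compound 1 gives 25000 nM.
Compound 2 `COc1ccccc1/C=C(/Sc1ccc(C)cc1)C(=O)c1ccc(Cl)cc1` — in this assay compound 2 gives 25000 nM.

Compound 1 and compound 2 share the same core and the same sulfur-bound 4-methylphenyl group, and in this assay both return the same number at the digits shown, so the two lie within the scatter of each other and nothing can be said of an order between them. Compound 1 thus stands level with its nearest neighbour, compound 2, with no change at the digits shown.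

Compound 3 `CCOc1ccc(/C=C(/SCc2ccc(C)cc2)C(=O)c2ccc(Cl)cc2)cc1OC` has not yet been measured in this assay. Its difference from compound 1 is a single change: 4-methylbenzyl in place of 4-methylphenyl on a sulfur

Among the compounds with values here, no step between two measured compounds is known here, so there is no measured guide for how a change on this sulfur moves the number. With compound 1 at 25000 nM and nothing pointing either way, the step from compound 1 to compound 3 is expected to be small, not beyond the scatter, in either direction. The step this estimate means is no change at the digits printed from compound 1 to compound 3 (within the scatter). Compound 3 is therefore estimated at 25000 nM, with a range from 8000 nM to 60000 nM.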

Compound 3, concentration for 50% growth inhibition: 25000 nM
Compound 3: the middle estimate sits on the measured number at the digits printed; the measured number falls inside the stated range.
By their numbers in this assay, from the lowest: compounds 1, 2 and 3 (each within the scatter of the next).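

Within the data shown here, compound 1 and compound 2 carry the same sulfur-bound 4-methylphenyl group, so the earlier compounds gave no reading of a change on this sulfur, and in this assay the step to 4-methylbenzyl now provides the first one: no change at the digits printed from compound 1 to compound 3 (within the scatter) for this single change. The swap keeps a six-membered aromatic ring of carbon with a methyl group on it, and neither group has any hydrogen-bond donors or acceptors, so this result shows only that this one replacement on the sulfur leaves the growth-inhibition number unmoved, and it sets no rule for other groups there. Nothing measured here offers an explanation for this result.

Still open, as far as these compounds go, is whether a group of a different kind on this sulfur, such as a chain ending in an amine or a carboxylic acid, would shift the number beyond the scatter. Also open, from the compounds shown here alone, is whether the same swap from 4-methylphenyl to 4-methylbenzyl would give the same outcome on the core of compound 2.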